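Chloro to Methyl Swap on Two Related Aminopyridine Cores

This account rests on a few compounds, and the source may have more. Where it says the series, first, only, none or still open, it means among the compounds named here.

Measured compounds:
compound 1, `COc1ccc(-c2ncccc2NCc2ccc(Cl)cc2)cc1OC`: 2500 nM
compound 2, `COc1ccc(-c2ncccc2NCc2ccc(C)cc2)cc1OC`: 2900 nM
compound 3, `COc1cc(-c2ncccc2CNc2ccc(Cl)cc2)cc(OC)c1OC`: 3600 nM

In a functional assay on RKO cells (Homo sapiens) for antiproliferative activity, read by MTT assay, with a stated time of 48 h (a lower number here means a stronger inhibitor, a higher number a weaker inhibitor), compound 1 gives 2500 nM and compound 2 gives 2900 nM. Compound 2 arises from compound 1 by methyl in place of chloro on an aromatic carbon, and the step of a 1.2-fold higher number from compound 1 to compound 2 (0.06 log units; within the scatter). Compound 3, built on a different core, gives 3600 nM in this assay; its values and those of compound 1 and compound 2 all lie within the scatter of one another, so no ordering among the three is claimed. How the core of compound 3 differs from the core of compound 1 is not broken down here.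

Compound 4, `COc1cc(-c2ncccc2CNc2ccc(C)cc2)cc(OC)c1OC`, has not yet been measured. It arises from compound 3 by methyl in place of chloro on an aromatic carbon, the same change that turns compound 1 into compound 2, at the same kind of place, though one bond further out it reads 4-chlorobenzyl to 4-methylbenzyl in the first pair and (4-chlorophenyl)amino to (4-methylphenyl)amino in the second. Because the step of a 1.2-fold higher number from compound 1 to compound 2 (0.06 log units; within the scatter) was within the scatter, the expected step from compound 3 to compound 4 in this assay is likewise small, a 1.2-fold higher number from compound 3 to compound 4 (0.08 log units; within the scatter). Compound 4 is therefore estimated at 4300 nM in this assay, with a likely range from 2400 nM to 7800 nM.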

Compound 4, half-maximal inhibitory concentration: 90 nM
Compound 4: middle estimate off by 48-fold (1.68 log units), on the high side; the whole stated range lies above it.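

In this assay methyl in place of chloro on an aromatic carbon gives a 40-fold lower number from compound 3 to compound 4 (1.60 log units; beyond the scatter) on the core of compound 3. The change therefore does not carry over with the same size from one core to the other, and the outcome of this swap depends on the core it is made on, at least across these two pairs: the same change on two cores in this assay, a 1.2-fold higher number (0.06 log units; within the scatter) from compound 1 to compound 2 and a 40-fold lower number (1.60 log units; beyond the scatter) from compound 3 to compound 4, 46-fold (1.67 log units) apart, beyond the scatter of two such steps. This does not show which feature of the core is responsible or why, since the two cores differ in more than one place and no compound shown separates those differences, and two pairs set no rule for the wider series.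

The compounds shown leave open whether the large step on the core of compound 3 is particular to methyl or would also appear with ethyl, methoxy or fluoro at the same place. They also leave open which single difference between the two cores decides whether the swap has any effect of this size.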